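Removing the Nitrate from a Sigma Receptor Binder

This account rests on a few compounds, and the source may have more. Where it says the series, first, only, none or still open, it means among the compounds named here.

Of the compounds shown here, three have been tested so far in an assay on isolated protein for displacement of a labelled ligand from Sigma intracellular receptor 2 (Homo sapiens), read by scintillation counting, with a stated time of 1 h, in the presence of a further agent that is not named here; on this read-out higher numbers stand for weaker inhibition and lower numbers for stronger inhibition. Compound 1 `O=C(NCCCCCN1CCC(Cc2ccccc2)CC1)c1cccc(CO[N+](=O)[O-])c1` gives 142 nM. Compound 2 `O=C(NCCCCN1CCC(Cc2ccccc2)CC1)c1ccc(CO[N+](=O)[O-])cc1` gives 89 nM. Compound 3 `O=C(NC1CCN(Cc2ccccc2)CC1)c1cccc(CO[N+](=O)[O-])c1` gives 19 nM. Among these, compound 2 holds the second highest of the three numbers; its nearest neighbour is compound 1, separated by a gap that stays within the usual scatter, so the two cannot be told apart, while compound 3 stands furthest away, with a number lower by a gap that lies beyond the scatter.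

Compound 4 `O=C(NCCCCN1CCC(Cc2ccccc2)CC1)c1ccc(CO)cc1` has not yet been measured. It differs from compound 2 in one place: hydrogen in place of nitro on an oxygen on a saturated carbon. Read one bond further out, the nitrooxy group becomes hydroxy, and the (nitrooxy)methyl group becomes hydroxymethyl. For the measured compounds named here, no pair of measured compounds shows this same change, so no measured step guides the expectation, and the shared core is untouched. Compound 4 is therefore expected to stay close to compound 2, with a small loss at most, and the expected step from compound 2 to compound 4 in this assay is a 1.7-fold higher number from compound 2 to compound 4 (0.23 log units; within the scatter). The estimate for compound 4 in this assay is 150 nM, within a range from 50 nM to 450 nM.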

Compound 4, inhibition constant: 2600 nM
The estimate for compound 4 lay 17-fold (1.24 log units) below the measured number; the measured number lies above the stated range.
By their numbers in this assay, from the lowest: compound 3; then compounds 2 and 1 (each within the scatter of the next); then compound 4.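

Putting hydrogen in place of nitro on this oxygen gives a 29-fold higher number from compound 2 to compound 4 (1.47 log units; beyond the scatter) in this assay, a large step that lies beyond the scatter. The earlier compounds shown here all carry the nitrooxy group, so they could not show how much the number depends on what sits at this position; here the shared core is untouched, and this one change, from (nitrooxy)methyl to hydroxymethyl, accompanies the whole step. Nothing available explains why the number moves so far.

The compounds shown leave open whether the step follows from losing the nitro or from gaining the hydrogen on the oxygen, a question that a methoxymethyl group at the same place could help to separate. From the compounds shown here alone, whether the same change would give a step of similar size on the core of compound 1 or of compound 3 also remains open.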